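Ethynyl for bromo on the sulfonamide aryl ring

The source may report more compounds than this note shows. Statements on the series, on what has been measured and on what is new or still open speak of the compounds shown alone.

Measured so far:
compound 1 `CC(=O)Nc1nc(-c2cccc(NS(=O)(=O)c3cccc(Br)c3)c2)cs1` — 67.4%
compound 2 `CC(=O)Nc1nc(-c2cccc(NS(=O)(=O)c3ccc(C#CC4CCCCC4)cc3)c2)cs1` — 1.2%

In a functional assay on A-375 cells (Homo sapiens) for antiproliferative activity, read by trypan blue exclusion, with a stated time of 48 h, tested at 5 uM (a lower number here means a stronger effect, a higher number a weaker effect of the compound at the concentration tested), compound 1 gives 67.4%, the highest of the two numbers, so the weakest effect seen; compound 2 gives 1.2%, a number far lower and beyond the scatter. For the measured compounds named here, no step between compounds differing in one place has been measured, so the pair shows only that the two values lie far apart.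

Compound 3 `C#Cc1cccc(S(=O)(=O)Nc2cccc(-c3csc(NC(C)=O)n3)c2)c1` is not yet measured. It differs from compound 1 as follows: ethynyl in place of bromo on an aromatic carbon. The group that enters carries a triple bond, as does the group on compound 2, but compound 2 differs from compound 1 in more than one place, so its value cannot be read as a step. A modest move toward a stronger effect is expected from compound 1 to compound 3, a number 12.4 percentage points lower from compound 1 to compound 3 (beyond the scatter), possibly within the scatter. For compound 3 the estimate in this assay is 55%, expected between 28% and 85%.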

Compound 3, a percentage reported as activity, at one concentration (the size of the read-out at that concentration, not a potency): 29%
Compound 3: the middle estimate sits 26 percentage points above what was measured; measured number inside the range.
By their numbers in this assay, from the lowest: compound 2; then compound 3; then compound 1.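

In this assay, replacing bromo with ethynyl on the aromatic carbon gives a number 38.4 percentage points lower from compound 1 to compound 3 (beyond the scatter) with the rest of the structure unchanged. For the compounds shown here, this is the first single-place step, and it shows that the group at this carbon, meta to the large group, can by itself shift the read-out at the concentration tested. Going by these compounds alone, the step is large and points toward a stronger effect, but it covers only this one exchange. No measurement here explains the shift.

As far as these compounds go, whether the triple bond itself matters stays open: a vinyl group, an ethyl group or a nitrile at the same carbon would test that. Also open, from the compounds shown here alone, is how a longer alkynyl chain at this carbon would compare with ethynyl in the same core.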